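Hydroxyalkylamino purine series: chain branching at the hydroxyalkyl group

The source may report more compounds than this note shows. Statements on the series, on what has been measured and on what is new or still open speak of the compounds shown alone.

Working notes on a small set built around a shared core. Compound 1 `CC(C)n1cnc2c(Nc3ccc(-c4cncnc4)cc3)nc(Cl)nc21` carries no reported result: in an assay on isolated protein (Asteroidea) for inhibition of G2/mitotic-specific cyclin-B (Asterina pectinifera), read by scintillation counting and 33P incorporation, with a stated time of 30 min (a lower number here means a stronger inhibitor, a higher number a weaker inhibitor), compound 1 shows "not determined" (no result reported). Compound 2 `CC(C)C[C@@H](O)Nc1nc(Nc2ccc(-c3ncccn3)cc2)c2ncn(C(C)C)c2n1` is in the same position: in this assay compound 2 shows "not determined" (no result reported). Within the data shown here, compound 3 `CCC[C@H](O)Nc1nc(Nc2ccc(-c3cncnc3)cc2)c2ncn(C(C)C)c2n1` is the only member with a number: in this assay compound 3 gives 70 nM, so it stands alone and nothing can be ranked against it. Compound 4 `CC(C)C[C@@H](O)Nc1nc(Nc2ccc(-c3cncnc3)cc2)c2ncn(C(C)C)c2n1` differs from compound 3 by 1-hydroxy-3-methylbutyl in place of 1-hydroxybutyl on a nitrogen on an aromatic ring. Among the measured compounds shown here, no measured pair shows this change, so the step is expected to stay within the usual scatter, with no clear direction. The step from compound 3 to compound 4 is therefore estimated as a 1.2-fold lower number from compound 3 to compound 4 (0.07 log units; within the scatter). For compound 4 the expected value in this assay is 60 nM, within 25 nM to 170 nM.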

Compound 4, half-maximal inhibitory concentration: 17 nM
Beside the measured number, compound 4's estimate is 3.5-fold (0.55 log units) above it; the measured number lies below the stated range.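

In this assay, 1-hydroxy-3-methylbutyl in place of 1-hydroxybutyl on a nitrogen on an aromatic ring gives a 4.1-fold lower number from compound 3 to compound 4 (0.61 log units; beyond the scatter), the first sign that activity responds to the hydroxyalkyl group at this position. The reading rests on this single pair, and hydrogen-bond donor and acceptor counts are the same in both groups. No measured evidence bears on the origin of this step.

Whether the branch or the longer chain carries the step remains open, as a straight 1-hydroxypentyl chain is not among the compounds shown. On these data alone, a 1-hydroxy-3-methylbutyl chain ending in an amine is also absent, so tolerance for such a group at this position is unknown.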